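The compounds below may be only part of what the source reports. "The series", "measured", "known", "first", "only" and "open" are said of these compounds alone.

Measured compounds:
Compound 1, `C[C@@H]1CN(c2sc(C(F)(F)F)nc2-c2nc3ccccc3[nH]2)CCN1C(=O)Cn1cccn1`: 13 nM
Compound 2, `C[C@@H]1CN(c2sc(C(F)(F)F)nc2-c2nc3ccccc3[nH]2)CCN1C(=O)Cn1cc(C2CCN(C)CC2)cn1`: 15 nM
Compound 3, `Cc1nc(C)n(CC(=O)N2CCN(c3sc(C(F)(F)F)nc3-c3nc4ccc(C(C)(C)O)c(F)c4[nH]3)C[C@H]2C)n1`: 9.4 nM

In a functional assay on CHO-K1 cells for antagonist activity at C-X-C chemokine receptor type 3 (Homo sapiens), read by FLIPR, with a stated time of 10 min, in the presence of a further agent that is not named here (on this read-out higher numbers stand for weaker inhibition and lower numbers for stronger inhibition), compound 2 gives the largest of the three numbers, but its gap to compound 1 and its gap to compound 3 are both within the scatter, so the three compounds cannot be told apart on these measurements.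

Compound 4, `C[C@@H]1CN(c2sc(C(F)(F)F)nc2-c2nc3ccccc3[nH]2)CCN1C(=O)CN1C(=O)OC[C@@H]1c1ccccc1`, differs from compound 2 by 2-oxo-4-phenyl-1,3-oxazolidin-3-yl in place of 4-(1-methylpiperidin-4-yl)-1H-pyrazol-1-yl on a saturated chain carbon bound to a carbonyl carbon. Among the compounds with values here, the only measured step that touches this part of the molecule is a 1.2-fold higher number from compound 1 to compound 2 (0.06 log units; within the scatter), which added the 1-methylpiperidin-4-yl group to the pyrazole that now leaves; that step stayed within the scatter. Within the data shown here, no measured step covers the 2-oxo-4-phenyl-1,3-oxazolidin-3-yl group that enters, nor any replacement of the whole ring on the saturated chain carbon bound to the carbonyl carbon. Given that the one step at this position was flat, the expectation for compound 4 is a step of a 1.3-fold higher number from compound 2 to compound 4 (0.12 log units; within the scatter), that is, no change beyond the scatter, with the range widened because the entering group has no precedent here. Compound 4 is therefore estimated at 20 nM, between 6 nM and 70 nM.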

Compound 4, half-maximal inhibitory concentration: 360 nM
The estimate for compound 4 lay 18-fold (1.26 log units) below the measured number; the measured number lies above the stated range.
By their numbers in this assay, from the lowest: compounds 3, 1 and 2 (each within the scatter of the next); then compound 4.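

In this assay, within the data shown here, the position on the saturated chain carbon bound to a carbonyl carbon turns out not to be flat, as the single earlier step, a 1.2-fold higher number from compound 1 to compound 2 (0.06 log units; within the scatter), had suggested: the change of ring gives a 24-fold higher number from compound 2 to compound 4 (1.38 log units; beyond the scatter), and measured against the unsubstituted pyrazole it gives a 28-fold higher number from compound 1 to compound 4 (1.44 log units; beyond the scatter). Both steps are large and beyond the scatter, so this position accepts the 1-methylpiperidin-4-yl group on the pyrazole yet does not accept every group put in place of the pyrazole, and the same count of heavy atoms in the leaving and entering groups does not preserve the number. Nothing among the data at hand accounts for this loss of inhibition.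

The compounds shown leave open which part of the 2-oxo-4-phenyl-1,3-oxazolidin-3-yl group goes with the higher number: the phenyl ring, the ring carbonyl and ring oxygen, or the defined stereocentre. They also leave open how a plain 2-oxo-1,3-oxazolidin-3-yl group without the phenyl, the opposite stereoisomer, or a 1H-imidazol-1-yl ring in place of the pyrazole would read at this position.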